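Aryl substitution in a succinimide series: from compound 1 to compound 4

The source may report more compounds than this note shows. Statements on the series, on what has been measured and on what is new or still open speak of the compounds shown alone.

Compound 1 `CC(C(=O)N1CCN(c2ccccc2)CC1)N1C(=O)CCC1=O`: 50%
Compound 2 `CCC(C(=O)N1CCN(c2cccc(OC)c2)CC1)N1C(=O)CCC1=O`: 0%
Compound 3 `CCC(C(=O)N1CCN(c2cccc(C(F)(F)F)c2)CC1)N1C(=O)CCC1=O`: 50%

In a functional assay on the whole organism (strain Swiss) with Mus musculus as the target, in the maximal electroshock model, with a stated time of 0.5 h, at a dose of 300 mg/kg by the intraperitoneal route (a higher number here means a stronger effect of the compound at the dose given, a lower number a weaker effect), compound 1 gives 50%. In this assay compound 3 gives 50%, level with compound 1 at the digits shown, and together they are the highest of the three numbers. Compound 2 gives 0%, the lowest. Among the measured compounds shown here, the single step between neighbouring measured compounds is a number 50 percentage points higher from compound 2 to compound 3 (beyond the scatter), a change of one group on an aromatic carbon.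

Compound 4 `CC(C(=O)N1CCN(c2ccccc2Cl)CC1)N1C(=O)CCC1=O` differs from compound 1 by chloro in place of hydrogen on an aromatic carbon. For the measured compounds named here, no measured pair shows chloro entering in place of hydrogen, so the step from compound 2 to compound 3 is the only guide, and it concerns a different exchange on the aromatic ring. Because that step a number 50 percentage points higher from compound 2 to compound 3 (beyond the scatter) shows how much one aromatic substituent can move this assay, a wide range is expected for compound 4, while the middle estimate stays where compound 1 stands. Compound 4 is therefore expected at 50%, between 15% and 85%, with an expected step of no change at the digits printed from compound 1 to compound 4 (within the scatter).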

Compound 4, a percentage reported as activity, at one dose (the size of the read-out at that dose, not a potency): 0%
Estimate against measurement, compound 4: 50 percentage points above, and the stated range ends above it.
By their numbers in this assay, from the lowest: compounds 2 and 4 (each within the scatter of the next); then compounds 1 and 3 (each within the scatter of the next).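

In this assay, going from phenyl to 2-chlorophenyl gives a number 50 percentage points lower from compound 1 to compound 4 (beyond the scatter), so a single chloro in place of hydrogen, ortho to a large group, is enough to remove the whole read-out seen for compound 1. Among the compounds shown here, until now, the only one-place step on the aromatic ring was trifluoromethyl in place of methoxy, whereas this step starts from the unsubstituted phenyl and shows that adding one atom at this place can matter as much as that exchange did. No measurement at hand explains the loss.

As far as these compounds go, whether fluoro or methyl at this same place would behave as chloro does remains open. From the compounds shown here alone, it is also open whether the loss would persist with chloro on another carbon of the ring, or with the same group on the core of compound 3.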